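The source may hold more compounds than are shown below. What is called first, only, known or untested is meant among the compounds shown, and "the series" means these compounds.

Three compounds share one core. Compound 1 `Cc1cc(C(=O)N2CCCCc3ccccc32)ccc1CNC(=O)Nc1ccccc1F` gives 30 nM in a functional assay on HEK293 cells for agonist activity at Vasopressin V2 receptor (Homo sapiens), read by a luciferase reporter and cAMP accumulation; a higher number here means that more compound is needed for the effect, a lower number that less compound is needed. Compound 2 `Cc1cc(C(=O)N2CCCCc3ccccc32)ccc1CNC(=O)Nc1ccccc1` gives 130 nM, and compound 3 `Cc1cc(C(=O)N2CCCCc3ccccc32)ccc1CNC(=O)NCC(=O)N1CCCC1` gives 100 nM. Among these three numbers compound 3 stands second highest, its nearest neighbour being compound 2 and its furthest compound 1. The step of a 4.3-fold higher number from compound 1 to compound 2 (0.64 log units; beyond the scatter) and the step of a 3.3-fold higher number from compound 1 to compound 3 (0.52 log units; beyond the scatter) were both modest, while the step of a 1.3-fold lower number from compound 2 to compound 3 (0.11 log units; within the scatter) stayed within the scatter.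

Compound 4 `Cc1cc(C(=O)N2CCCCc3ccccc32)ccc1CNC(=O)N1CCC[C@H]1C(=O)OC(C)C` differs from compound 3 by 2-(isopropoxycarbonyl)pyrrolidin-1-yl in place of (((pyrrolidin-1-yl)carbonyl)methyl)amino on a carbonyl carbon. Among the measured compounds shown here, the two steps that alter the substituent on that amide-type nitrogen, from compound 1 and from compound 2 to compound 3, bear on this change, but neither removes the hydrogen-bond donor as this change does, so no measured step covers it directly. Compound 4 is therefore expected to land near compound 3 or somewhat above it, a step of a 1.6-fold higher number from compound 3 to compound 4 (0.20 log units; within the scatter). The estimate for compound 4 in this assay is 160 nM, within a range from 40 nM to 650 nM.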

Compound 4, half-maximal effective concentration: 950 nM
For compound 4 the middle estimate is 5.9-fold (0.77 log units) below the measured one; the whole stated range lies below it.
By their numbers in this assay, from the lowest: compound 1; then compounds 3 and 2 (each within the scatter of the next); then compound 4.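

On a carbonyl carbon whose other neighbour is an amide-type nitrogen, 2-(isopropoxycarbonyl)pyrrolidin-1-yl gives the highest number of the four in this assay, with a 9.5-fold higher number from compound 3 to compound 4 (0.98 log units; beyond the scatter) and a 7.3-fold higher number from compound 2 to compound 4 (0.86 log units; beyond the scatter) and the largest step of the series in a 32-fold higher number from compound 1 to compound 4 (1.50 log units; beyond the scatter) at this place. Among the compounds shown here, both the group that leaves compound 3 and the one that enters compound 4 hold a five-membered non-aromatic ring, so such a ring in the substituent does not by itself keep the number near that of compound 3, and the change with no hydrogen-bond donor in the entering group is the first to go this far. Nothing shown explains this rise.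

The compounds leave open whether the lost amide hydrogen, the isopropoxycarbonyl group or the defined stereocentre accounts for the step. A carboxylic acid or a methyl ester in place of the isopropoxycarbonyl group would help to separate these.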